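This account rests on a few compounds, and the source may have more. Where it says the series, first, only, none or still open, it means among the compounds named here.

Compound 1 `Cn1nccc1-c1ccccc1NCC1=NCCN1` stands lowest of the two compounds measured in a functional assay with Alpha-1D adrenergic receptor (Homo sapiens) as the target, read by calcium flux (a lower number here means a smaller maximal response, a higher number a larger maximal response), where compound 1 gives 0%. For the measured compounds named here, the only measured comparison is compound 2 `Cn1ccc(-c2ccccc2NCC2=NCCN2)n1`, which in this assay gives 29%. The change between them, a number 29 percentage points higher from compound 1 to compound 2 (beyond the scatter), comes from 1-methyl-1H-pyrazol-3-yl in place of 1-methyl-1H-pyrazol-5-yl on an aromatic carbon. Compound 3 `CCCn1nccc1-c1ccccc1NCC1=NCCN1` is not yet measured. It differs from compound 1 by ethyl in place of hydrogen on a saturated chain carbon bound to an aromatic nitrogen. Going by the values given here, no measured step speaks to this kind of change: the one known step swaps the attachment of the aromatic group, and leaves the saturated chain carbon bound to an aromatic nitrogen untouched. With nothing to lean on, the step expected for compound 3 is one of no size beyond the scatter, a number 5 percentage points higher from compound 1 to compound 3 (within the scatter). Compound 3 is therefore estimated at 5% in this assay, within a range from 0% to 25%.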

Compound 3, largest response reached (reported as maximal response), in percent of the reference or control that the assay uses: 0%
Beside the measured number, compound 3's estimate is 5 percentage points above it; low and high end bracket the measured number.
By their numbers in this assay, from the lowest: compounds 1 and 3 (each within the scatter of the next); then compound 2.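

The step of ethyl in place of hydrogen on a saturated chain carbon bound to an aromatic nitrogen gives no change at the digits printed from compound 1 to compound 3 (within the scatter) in this assay. For the compounds shown here, this is the first reading at this place, as the earlier pair changed only the attachment of the aromatic group, and it shows that the chain going from methyl to propyl raises no response above that of compound 1, which stands at 0%. No evidence is available that explains this reading.

Left open is whether the same change would also leave the number unmoved on the attachment found in compound 2. Also open, as far as these compounds go, is whether a longer chain, or an amine or a carboxylic acid carried at this place, would lift the number above that of compound 1.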